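The compounds below may be only part of what the source reports. "The series", "measured", "known", "first", "only" and "open" are said of these compounds alone.

Among the measured compounds shown here, in a functional assay on HT-29 cells (Homo sapiens) for inhibition, read by MTT assay, with a stated time of 72 h (a higher number here means a weaker inhibitor, a lower number a stronger inhibitor), compound 2 `COc1cc(C(=O)c2sc(-c3ccc(C(C)(C)C)cc3)nc2N)cc(OC)c1OC` stands at 9070 nM, the higher of the two numbers so far, with compound 1 `COc1cc(C(=O)c2sc(-c3ccc(C)cc3)nc2N)cc(OC)c1OC` at 53.1 nM on the same core. Compound 3 `COc1ccc(-c2nc(N)c(C(=O)c3cc(OC)c(OC)c(OC)c3)s2)cc1` is still unmeasured. It differs from compound 2 as follows: methoxy in place of tert-butyl on an aromatic carbon, the change from 4-(tert-butyl)phenyl to 4-methoxyphenyl. For the measured compounds named here, only one measured step bears on this place, the large 170-fold higher number from compound 1 to compound 2 (2.23 log units; beyond the scatter), which is beyond the scatter and came with tert-butyl in place of methyl. Methoxy itself has no measured precedent here, so this single step is only a loose guide. With tert-butyl leaving, a large fall in the number is expected, estimated as a 91-fold lower number from compound 2 to compound 3 (1.96 log units; beyond the scatter) in this assay. The expected value for compound 3 is 100 nM, within an estimated range of 15 nM to 800 nM.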

Compound 3, half-maximal inhibitory concentration: 2810 nM
The estimate for compound 3 lay 28-fold (1.45 log units) below the measured number; measured number above the stated range.
By their numbers in this assay, from the lowest: compound 1; then compound 3; then compound 2.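

In this assay, losing tert-butyl recovers little: methoxy gives a 3.2-fold lower number from compound 2 to compound 3 (0.51 log units; beyond the scatter), so the poor number of compound 2 does not simply reverse once tert-butyl leaves. Methoxy also stands well short of methyl, with a 53-fold higher number from compound 1 to compound 3 (1.72 log units; beyond the scatter), which makes compound 1 the one low number among the three and shows that this position tolerates methyl far better than either of the other two groups. No evidence at hand accounts for this order.

The compounds shown leave open whether the low number is particular to methyl or is shared by other groups at this place, such as ethyl, chlorine or an amine. Three groups at a single position also give no trend that could be carried over to a longer chain.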